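Swapping the Benzyl Substituent of a Shared Amide Core

The source may report more compounds than this note shows. Statements on the series, on what has been measured and on what is new or still open speak of the compounds shown alone.

Measured so far:
compound 1 `N[C@H]1CC[C@H](Nc2c(C(=O)NCc3ccco3)nc(Br)c3cccnc23)CC1` — 10000 nM
compound 2 `N[C@H]1CC[C@H](Nc2c(C(=O)NCc3cccc(C(F)(F)F)c3)nc(Br)c3cccnc23)CC1` — "not determined" (no result reported)
compound 3 `COC(=O)CNc1c(C(=O)NCc2ccc(F)cc2)nc(Br)c2cccnc12` — 1000 nM

The series was tested in a functional assay on SK-BR-3 cells (Homo sapiens) for cytotoxicity, read by MTT assay, with a stated time of 72 h; a lower number here means a stronger inhibitor, a higher number a weaker inhibitor. Compound 1 gives 10000 nM there, while compound 3 gives 1000 nM. Compound 2 stands nowhere on these numbers: for compound 2 the entry reads "not determined" (no result reported), so the step to compound 4 `COc1ccc(CNC(=O)c2nc(Br)c3cccnc3c2N[C@H]2CC[C@H](N)CC2)cc1` cannot be anchored on its own value.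

The change from compound 2 to compound 4 is 4-methoxyphenyl in place of 3-(trifluoromethyl)phenyl on a saturated chain carbon bound to an amide-type nitrogen. The rest of the molecule, including the diamino-substituted cyclohexyl group that compound 4 shares with compound 1, is unchanged.

Among the compounds with values here, with no measured step for this pair, the expectation rests on the two numbers that exist. Compound 4 shares its cyclohexyl amine with compound 1, which carries a furanylmethyl amide and gives a weak 10000 nM. Compound 3, with a benzyl-type amide and a different amine, gives 1000 nM. Compound 4 combines a benzyl-type amide with the amine of compound 1, so it is expected to land between these two, and any difference from compound 2 is expected to stay within the scatter or be modest at most. Compound 4 is estimated to give about 4000 nM in this assay, in the range 1200 nM to 15000 nM.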

Compound 4, half-maximal inhibitory concentration: 5000 nM
The estimate for compound 4 lay 1.3-fold (0.10 log units) below the measured number, and the stated range covers the measured number.
By their numbers in this assay, from the lowest: compound 3; then compounds 4 and 1 (each within the scatter of the next).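

Within the data shown here, with the cyclohexyl amine held fixed, compound 1 and compound 4 form the first pair in this assay that differs at this position alone, and the reading is a 2.0-fold lower number from compound 1 to compound 4 (0.30 log units; within the scatter) on exchanging furan-2-yl for 4-methoxyphenyl on a saturated chain carbon bound to an amide-type nitrogen. This exchange of one aromatic ring for another therefore does not separate the two compounds, so a six-membered aromatic ring carrying a methoxy group and a furan ring cannot be told apart at this position in these cells. The step from compound 2 to compound 4 cannot be read, as compound 2 has no reported result, so the effect of 3-(trifluoromethyl)phenyl at this position remains unknown, and nothing measured here accounts for the outcome.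

The compounds shown leave open whether any group at this position would move the number beyond the scatter while the cyclohexyl amine stays in place, for example a benzyl ring carrying a carboxylic acid, or a longer chain between the amide nitrogen and the aromatic ring. They also leave open whether 4-methoxyphenyl would behave the same way with the glycine methyl ester side chain of compound 3 in place of the cyclohexyl amine.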